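From 4-methylphenyl to 4-methoxyphenyl: compound 3 and compound 4

The compounds below may be only part of what the source reports. "The series", "measured", "known", "first", "only" and "open" are said of these compounds alone.

Of the compounds shown here, three on one shared core have been measured in a functional assay on HepG2 cells (Homo sapiens) for inhibition, read by MTT assay; on this read-out lower numbers stand for stronger inhibition of growth and higher numbers for weaker inhibition of growth. Compound 1 `COc1cc2oc(-c3cccc(NC(=O)c4ccc(F)cc4)c3)cc(=O)c2c(OC)c1OC` carries fluoro on an aromatic carbon (47200 nM). Compound 2 `COc1cc2oc(-c3cccc(NC(=O)c4ccc(C(F)(F)F)cc4)c3)cc(=O)c2c(OC)c1OC` carries trifluoromethyl there (61100 nM). Compound 3 `COc1cc2oc(-c3cccc(NC(=O)c4ccc(C)cc4)c3)cc(=O)c2c(OC)c1OC` carries methyl there (9750 nM) and has the lowest of the three numbers, with both gaps to the others beyond the scatter.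

Compound 4 `COc1ccc(C(=O)Nc2cccc(-c3cc(=O)c4c(OC)c(OC)c(OC)cc4o3)c2)cc1` has not yet been measured. It has methoxy in place of methyl on an aromatic carbon, para to a large group (methoxy in place of methyl on an aromatic carbon).

All three measured steps change this same carbon, but none involves methoxy, so they offer a guide to size and only a weak one to direction. The first, a 1.3-fold higher number from compound 1 to compound 2 (0.11 log units; within the scatter), stays within the scatter. The other two, a 4.8-fold lower number from compound 1 to compound 3 (0.68 log units; beyond the scatter) and a 6.3-fold lower number from compound 2 to compound 3 (0.80 log units; beyond the scatter), are both modest and both end at compound 3. Among these three compounds, replacing methyl has each time given a higher number. A small rise is therefore expected, with an estimated 1.6-fold higher number from compound 3 to compound 4 (0.22 log units; within the scatter) that could still fall within the scatter. Compound 4 is expected at about 16000 nM (estimated range 6000 nM to 45000 nM).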

Compound 4, concentration for 50% growth inhibition: 22200 nM
Compound 4: middle estimate off by 1.4-fold (0.14 log units), on the low side; the range from low to high includes it.
By their numbers in this assay, from the lowest: compound 3; then compound 4; then compounds 1 and 2 (each within the scatter of the next).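

In this assay, for the compounds shown here, the methoxy result extends what the earlier compounds showed only for fluoro and trifluoromethyl: with a 2.3-fold higher number from compound 3 to compound 4 (0.36 log units; beyond the scatter), a third replacement of methyl on this aromatic carbon, para to a large group, also gives a higher number, and one that lies beyond the scatter. Methoxy is also set apart from the other two groups, with a 2.8-fold lower number from compound 2 to compound 4 (0.44 log units; beyond the scatter) and a 2.1-fold lower number from compound 1 to compound 4 (0.33 log units; beyond the scatter), so it does not simply join them at the upper end of the series. The four compounds therefore fall into three levels at this one carbon: methyl lowest, methoxy in the middle, and fluoro and trifluoromethyl together at the top, since the two of them stand within the scatter of each other.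

No measurement shown here bears on why the groups fall in this order. From the compounds shown here alone, it remains open whether an ethyl, a hydroxy or an amino group on this carbon would match methyl or give a higher number, and whether the same order would hold on a different cell line.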